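A few compounds are considered here, and "the series" means these few. Any claim that something is new, unique, unknown or untested is made for them only; others in the source may bear on it.

In a functional assay on MDA-MB-231 cells (Homo sapiens) for cytotoxicity, read by MTT assay, with a stated time of 72 h (a higher number here means a weaker inhibitor, a lower number a stronger inhibitor), three compounds have been measured:

compound 1 `O=C(CN1CCN(c2nnc(Cc3ccncc3)c3ccccc23)CC1)Nc1cccc(F)c1` gives 4.4 nM
compound 2 `O=C(CN1CCN(c2nnc(Cc3ccncc3)c3ccccc23)CC1)Nc1ccc(Br)cc1` gives 19 nM
compound 3 `COc1ccc(NC(=O)CN2CCN(c3nnc(Cc4ccccc4)c4ccccc34)CC2)cc1OC` gives 32200 nM

For the measured compounds named here, compound 3 stands at the highest number of the three, far from compound 2 and further still from compound 1, and no single-place step connects it to either of them. Compound 4 `O=C(CN1CCN(c2nnc(Cc3ccccc3)c3ccccc23)CC1)Nc1ccc(F)c(C(F)(F)F)c1` is the unmeasured compound; it carries the change (4-fluoro-3-(trifluoromethyl)phenyl in place of 3,4-dimethoxyphenyl on an amide-type nitrogen). Going by the values given here, the only measured step bears on it indirectly: a 4.3-fold higher number from compound 1 to compound 2 (0.64 log units; beyond the scatter), also an exchange of one aryl group on an amide-type nitrogen, and it was modest. That step does not show what a 3,4-dimethoxyphenyl in place of a halogenated phenyl does, nor does it share the core of compound 3, so the size of the coming step is largely unknown. What the numbers show is that compounds 1 and 2, each with a halogenated phenyl on the amide-type nitrogen, sit low, while compound 3 with its 3,4-dimethoxyphenyl sits very high. Compound 4 is therefore expected to give a lower number than compound 3, by a step estimated at a 5.4-fold lower number from compound 3 to compound 4 (0.73 log units; beyond the scatter), with wide uncertainty. Compound 4 is estimated at 6000 nM, in a range from 600 nM to 32000 nM.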

Compound 4, half-maximal inhibitory concentration: 760 nM
The estimate for compound 4 lay 7.9-fold (0.90 log units) above the measured number; the measured number falls inside the stated range.
By their numbers in this assay, from the lowest: compound 1; then compound 2; then compound 4; then compound 3.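

In this assay, the exchange of 3,4-dimethoxyphenyl for 4-fluoro-3-(trifluoromethyl)phenyl on an amide-type nitrogen gives a 42-fold lower number from compound 3 to compound 4 (1.63 log units; beyond the scatter). For the compounds shown here, this is the first measured step on the core of compound 3, and it shows that the aryl group at this position can shift the number substantially on that core, by a large step where a 4.3-fold higher number from compound 1 to compound 2 (0.64 log units; beyond the scatter) on the core of compound 1 was modest. Nothing available accounts for the size of this step.

The compounds shown leave open whether the step comes from losing the methoxy groups, from gaining the fluorine and the trifluoromethyl group, or from both together, and whether the same exchange would have a similar size on the core of compound 1. They also leave open how this position responds to an aryl group carrying an amine or a carboxylic acid, or to a longer chain between the amide-type nitrogen and the ring.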